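A new group on the carbonyl carbon of compound 3

This account rests on a few compounds, and the source may have more. Where it says the series, first, only, none or still open, it means among the compounds named here.

Measured in a functional assay on HeLa cells (Homo sapiens) for antiproliferative activity, with a stated time of 24 h; on this read-out lower numbers stand for stronger inhibition and higher numbers for weaker inhibition:
Compound 1 `NC(=O)c1c(NC(=O)c2ccccc2Cl)sc2c1CCN(Cc1ccc(Cl)cc1)C2`: > 50000 nM, a limit of the assay
Compound 2 `NC(=O)c1c(NC(=O)c2ccccc2Cl)sc2c1CCN(Cc1c(Cl)cccc1Cl)C2`: 28800 nM
Compound 3 `NC(=O)c1c(NC(=O)c2ccccc2Cl)sc2c1CCN(Cc1ccc(Cl)cc1Cl)C2`: 21100 nM

Compound 3 stands level with compound 2, the gap being a 1.4-fold lower number from compound 2 to compound 3 (0.14 log units; within the scatter). Compound 4 `Cc1ccc(C(=O)Nc2sc3c(c2C(N)=O)CCN(Cc2ccc(Cl)cc2Cl)C3)cc1` carries 4-methylphenyl in place of 2-chlorophenyl on a carbonyl carbon. The measured steps, an at least 1.7-fold lower number from compound 1 to compound 2 (0.23 log units; that floor lies within the scatter) and an at least 2.3-fold lower number from compound 1 to compound 3 (0.37 log units; beyond the scatter) among them, all alter the chlorinated phenyl group at the other end of the molecule. None tests this change, so the expectation rests on compound 3 at 21100 nM. No step beyond the scatter is expected, and the estimated result is a 1.1-fold lower number from compound 3 to compound 4 (0.02 log units; within the scatter). For compound 4 the expected value is 20000 nM, within an estimated range of 6000 nM to 50000 nM.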

Compound 4, half-maximal inhibitory concentration: > 50000 nM
Compound 4 ended at the assay's limit; the forecaster's own chance of this, stated with the estimate: 20%; at least 2.5-fold (0.39 log units) between middle value and limit.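

In this assay, the group on the carbonyl carbon proves not to be indifferent: with the 2,4-dichlorophenyl end held fixed, the change gives an at least 2.3-fold higher number from compound 3 to compound 4 (0.37 log units; beyond the scatter). This is the only step shown away from the chlorinated phenyl group at the other end of the molecule, and it weakens inhibition. Compound 4 gives > 50000 nM, a limit of the assay: the limit of > 50000 nM in this assay, at which 2 of the 4 values shown sit.

The change removes a chlorine and adds a methyl in one step, so the compounds shown do not separate the two. Going by these compounds, whether a plain phenyl or a methoxyphenyl on this carbonyl carbon would keep the value of compound 3 remains open.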